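This account rests on a few compounds, and the source may have more. Where it says the series, first, only, none or still open, it means among the compounds named here.

In an ADME assay on Vero cells (Chlorocebus sabaeus) for cytotoxicity, with a stated time of 7 days (on this read-out higher numbers stand for lower toxicity in this test and lower numbers for higher toxicity in this test), compound 2 `COc1ccc2[nH]c(C(=O)N3CC(=O)N(Cc4ccccc4)[C@@H](CN4CC5CC5C4)C3)cc2c1` gives 13800 nM, the higher of the two numbers recorded, though compound 1 `COc1ccc2[nH]c(C(=O)N3CC(=O)N(Cc4ccccc4)[C@@H](CN4CC5CCCC5C4)C3)cc2c1` with 10600 nM lies within the scatter of it. Compound 3 `COc1ccc2[nH]c(C(=O)N3CC(=O)N(Cc4ccccc4)[C@@H](CN4CCCc5ccccc54)C3)cc2c1` differs from compound 2 in a group of 10 heavy atoms (9 carbon, 1 nitrogen; one six-membered non-aromatic ring with 1 hetero atom, one six-membered aromatic ring of carbon only) in place of a group of 6 heavy atoms (5 carbon, 1 nitrogen; one three-membered non-aromatic ring of carbon only, one five-membered non-aromatic ring with 1 hetero atom), on a saturated chain carbon bound to a saturated ring carbon. Among the measured compounds shown here, the only measured step at this place is a 1.3-fold higher number from compound 1 to compound 2 (0.11 log units; within the scatter), an exchange of one group for another that moved nothing beyond the scatter. Compound 3 brings in the 1,2,3,4-tetrahydroquinolin-1-yl group, yet the recorded steps give no ground for expecting a step beyond the scatter in this assay. Compound 3 is therefore estimated at 12000 nM (range 5000 nM to 30000 nM), a step of a 1.2-fold lower number from compound 2 to compound 3 (0.06 log units; within the scatter).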

Compound 3, half-maximal cytotoxic concentration: > 100000 nM
Compound 3: no number, only a limit; the forecaster's own chance of this, stated with the estimate: 10%; at least 8.3-fold (0.92 log units) between middle value and limit.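

In this assay, a change on the saturated chain carbon bound to a saturated ring carbon can move the read-out beyond the scatter, which the earlier exchange did not show: the 1,2,3,4-tetrahydroquinolin-1-yl group gives an at least 7.2-fold higher number from compound 2 to compound 3 (0.86 log units; beyond the scatter) and an at least 9.4-fold higher number from compound 1 to compound 3 (0.97 log units; beyond the scatter). For compound 3 there is no number, only a limit of the assay: the limit of > 100000 nM in this assay, at which 1 of the 3 values shown sits.

As far as these compounds go, how far the true value of compound 3 lies from that limit stays open. Also open, from the compounds shown here alone, is whether a piperidin-1-yl group, which lacks the six-membered aromatic ring, would give a similar step.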